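The source may hold more compounds than are shown below. What is called first, only, known or untested is meant among the compounds shown, and "the series" means these compounds.

Compound 1 `CC(C)(C)OC(=O)NC1CCCN(C(=O)CN2CN(c3ccccc3)C3(CCN(C(=O)c4ccc(C5CCCCC5)cc4)CC3)C2=O)C1` gives 4400 nM in an assay on HEK293 cells for displacement of a labelled ligand from NPC1-like intracellular cholesterol transporter 1 (Homo sapiens); a lower number here means a stronger inhibitor, a higher number a weaker inhibitor. Compound 2 `CC1(C)CC(OC(=O)CN2CN(c3ccccc3)C3(CCN(C(=O)c4ccc(C(C)(C)C)cc4)CC3)C2=O)CC(C)(C)N1` gives 1300 nM in this assay. Compound 3 `CCc1nn(CC)c(C2CCN(C(=O)CN3CN(c4ccccc4)C4(CCN(C(=O)c5ccc(C6CCCCC6)cc5)CC4)C3=O)CC2)c1C` gives "not determined" (no result reported) in this assay.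

In this assay compound 2 gives 1300 nM, the lowest of the two numbers recorded. Its nearest neighbour is compound 1, which in this assay gives 4400 nM, a higher number that lies beyond the usual scatter. For compound 3 the entry in this assay is "not determined" (no result reported), so no number is available for it.

Compound 4 `CC(C)(C)c1ccc(C(=O)N2CCC3(CC2)C(=O)N(CC(=O)N2CCCCC2CCO)CN3c2ccccc2)cc1` differs from compound 2 at one place: 2-(2-hydroxyethyl)piperidin-1-yl in place of (2,2,6,6-tetramethylpiperidin-4-yl)oxy on a carbonyl carbon. Among the compounds with values here, no measured pair shows this kind of change on its own, so the direction of the step has to be judged from the two numbers alone. Compound 1 differs from compound 2 at more than one place and gives no clean guide. Compound 4 is therefore expected to give a somewhat higher number, a step estimated at a 1.9-fold higher number from compound 2 to compound 4 (0.28 log units; within the scatter), though a result within the scatter would not be surprising. Compound 4 is estimated at 2500 nM, with a range from 800 nM to 8000 nM.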

Compound 4, half-maximal inhibitory concentration: 6100 nM
Estimate against measurement, compound 4: 2.4-fold (0.39 log units) below, and the stated range covers the measured number.
By their numbers in this assay, from the lowest: compound 2; then compounds 1 and 4 (each within the scatter of the next).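

In this assay, within the data shown here, this is the first step that changes only one place, and it gives a 4.7-fold higher number from compound 2 to compound 4 (0.67 log units; beyond the scatter), so the group on this carbonyl carbon does bear on the number. Both groups hold one six-membered non-aromatic ring with 1 hetero atom, 1 hydrogen-bond donor and no net charge, so these shared features alone do not fix the number; they differ in having 9 against 11 heavy atoms and 1 against 2 hydrogen-bond acceptors. No measurement shown ties the step to any one of these differences.

A single step cannot separate the way the ring is attached from the presence of the 2-hydroxyethyl chain. Open too, on these data alone, is how an unsubstituted piperidin-1-yl, or a carboxylic acid at the end of that chain, would read at this place.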